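The source may hold more compounds than are shown below. What is called first, only, known or untested is meant among the compounds shown, and "the series" means these compounds.

Compound 2 `CC(C)(C)OC(=O)CN1C(=O)C(NC(=O)c2cc3ccccc3[nH]2)CCc2ccccc21` gives the lowest of the two numbers recorded in an assay for binding affinity to Cholecystokinin receptor (Rattus norvegicus), read by CCK-8 assay (a lower number here means a stronger inhibitor, a higher number a weaker inhibitor), with compound 2 at 7 nM. For the measured compounds named here, its nearest neighbour in this assay is compound 1 `CC(C)(C)OC(=O)CN1C(=O)C(NC(=O)c2ccc(Cl)c(Cl)c2)CCc2ccccc21`, which in this assay gives 28 nM; the only measured step, a 4.0-fold lower number from compound 1 to compound 2 (0.60 log units; beyond the scatter), replaces a ring on the carbonyl carbon and is beyond the scatter.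

Compound 3 `CCOC(=O)CN1C(=O)C(NC(=O)c2cc3ccccc3[nH]2)CCc2ccccc21` differs from compound 2 at the other end of the molecule: ethyl in place of tert-butyl on an oxygen next to a carbonyl group. Going by the values given here, that change is ethyl in place of tert-butyl on an oxygen next to a carbonyl group, and no measured step touches that position. Among the compounds with values here, the one step available, from a dichlorophenyl ring to an indolyl ring, says nothing about the ester end, so no size of step in this assay can be taken from it. With the carbonyl and the oxygen retained and only the alkyl group shortened, compound 3 is expected to stay close to compound 2, and the step is estimated as a 1.4-fold higher number from compound 2 to compound 3 (0.15 log units; within the scatter), not beyond the scatter. Compound 3 is therefore estimated at 10 nM, with a range from 3 nM to 35 nM.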

Compound 3, half-maximal inhibitory concentration: 110 nM
Beside the measured number, compound 3's estimate is 11-fold (1.04 log units) below it, and the stated range ends below it.
By their numbers in this assay, from the lowest: compound 2; then compound 1; then compound 3.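

In this assay, this position proves sensitive to the alkyl group on the ester: a 16-fold higher number from compound 2 to compound 3 (1.20 log units; beyond the scatter) is a large step beyond the scatter, although the carbonyl and its oxygen stay in place. For the compounds shown here, the earlier step concerned only the group on the amide carbonyl carbon, so this is the first reading at the ester end, and it shows that the change from tert-butyl, with 4 heavy atoms, to ethyl, with 2, is not neutral with the 1H-indol-2-yl group held fixed. Going by these compounds alone, nothing available bears on why this alkyl change moves the number so far.

The compounds shown give only these two alkyl groups on this oxygen, so they leave open whether the number changes gradually or abruptly between ethyl and tert-butyl, and how isopropyl, a longer chain such as n-butyl, or a free carboxylic acid in place of the ester would read. They also leave open whether the same change would give a step of similar size with 3,4-dichlorophenyl on the amide carbonyl carbon.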